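Swapping the aryl group on a silyl ether compound

A few compounds are considered here, and "the series" means these few. Any claim that something is new, unique, unknown or untested is made for them only; others in the source may bear on it.

Measured in an ADME assay on L132 cells (Homo sapiens) for cytotoxicity, read by MTT assay, with a stated time of 72 h; on this read-out lower numbers stand for stronger inhibition and higher numbers for weaker inhibition:
- compound 1 `COc1ccc(OC)c(C2=C(c3cc(OC)c(OC)c(OC)c3)C(=O)CC2O[SiH2]C(C)(C)C)c1`: 100 ug/mL
- compound 2 `COc1ccc(C2=C(c3cc(OC)c(OC)c(OC)c3)C(=O)C(O[SiH2]C(C)(C)C)C2)cc1OC(C)C`: 7 ug/mL
- compound 3 `COc1ccc(OC)c(C2=C(c3cc(OC)c(OC)c(OC)c3)C(=O)CC2O)c1`: > 100 ug/mL (a limit of the assay)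

Of the two exact numbers in this assay, compound 1 holds the higher, at 100 ug/mL, and compound 2 the lower, at 7 ug/mL. Compound 3 gives > 100 ug/mL, which is a limit and not a number.

Compound 4 `COc1ccc(C2=C(c3cc(OC)c(OC)c(OC)c3)C(=O)CC2O[SiH2]C(C)(C)C)cc1O` is not yet measured. It keeps the core of compound 1 and differs by 3-hydroxy-4-methoxyphenyl in place of 2,5-dimethoxyphenyl on a double-bonded ring carbon.

Going by the values given here, the one measured step, a number no lower from compound 1 to compound 3 (the limit leaves the size open), changes a different place and leaves the 2,5-dimethoxyphenyl group as it is, so it sets no size for this change. Compound 2, at 7 ug/mL, offers the only hint: it lacks the 2,5-dimethoxyphenyl group, though it also differs from compound 1 elsewhere. On this weak ground a lower number is expected in this assay, with an estimated 3.3-fold lower number from compound 1 to compound 4 (0.52 log units; beyond the scatter). For compound 4 the estimated value is 30 ug/mL, with an expected range of 6 ug/mL to 100 ug/mL.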

Compound 4, half-maximal inhibitory concentration: < 1 ug/mL
Compound 4: no number, only a limit; the forecaster's own chance of this, stated with the estimate: 20%; middle value at least 30-fold (1.47 log units) from the limit.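

In this assay, exchanging 2,5-dimethoxyphenyl for 3-hydroxy-4-methoxyphenyl on a double-bonded ring carbon gives an at least 100-fold lower number from compound 1 to compound 4 (2.00 log units; beyond the scatter). Going by these compounds alone, this is the first single-place change at this position, since the one earlier step altered the silyl ether and compound 2 differed from compound 1 in more than one place, and it shows that this aryl exchange alone can move the read-out by a large amount. Compound 4 stands at a limit of the assay and not at a number, so the full size of the step remains open: the limit of < 1 ug/mL in this assay, at which 1 of the 4 values shown sits.

The compounds shown cannot separate the gain of the hydroxyl group from the changed arrangement of the ring's other oxygen substituents. They also leave open whether an amine or a fluorine in place of that hydroxyl would give a similar result, and whether the exchange would have the same effect on the core without the silyl ether.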